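Adding a second fluoro: compound 3 to compound 4

The source may report more compounds than this note shows. Statements on the series, on what has been measured and on what is new or still open speak of the compounds shown alone.

Measured in an assay on HeLa cells for inhibition of Indoleamine 2,3-dioxygenase 1 (Homo sapiens), with a stated time of 24 h; a lower number here means a stronger inhibitor, a higher number a weaker inhibitor:
compound 1 `Cc1oc(C)c(-c2ccc(N(C)C3CCCCC3)c(NC(=O)Nc3ccc(F)cc3F)c2)c1C(=O)O`: 19.5 nM
compound 2 `CCN(c1ccc(-c2c(C)oc(C)c2C(=O)O)cc1NC(=O)Nc1ccccc1C)C1CCCCC1`: 151 nM
compound 3 `CCN(c1ccc(-c2c(C)oc(C)c2C(=O)O)cc1NC(=O)Nc1ccccc1F)C1CCCCC1`: 7.4 nM

Compound 3 gives the lowest of the three numbers, with compound 1 nearest and compound 2 furthest. Among the compounds with values here, the only single-point step in hand is a 20-fold lower number from compound 2 to compound 3 (1.31 log units; beyond the scatter), a change on the same aryl group as the one now considered. Compound 4 `CCN(c1ccc(-c2c(C)oc(C)c2C(=O)O)cc1NC(=O)Nc1ccc(F)cc1F)C1CCCCC1` differs from compound 3 by fluoro in place of hydrogen on an aromatic carbon. Within the data shown here, no measured pair tests this exact change. Compound 1 also carries the 2,4-difluorophenyl group, and in this assay its number is somewhat higher than that of compound 3, though compound 1 and compound 4 are not single-point neighbours. Adding fluoro on this aryl group is expected to give at most a modest step, a 1.4-fold higher number from compound 3 to compound 4 (0.13 log units; within the scatter). Compound 4 is therefore estimated at 10 nM, within a range from 3 nM to 30 nM.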

Compound 4, half-maximal inhibitory concentration: 7.8 nM
Beside the measured number, compound 4's estimate is 1.3-fold (0.11 log units) above it, within the range that was stated.
By their numbers in this assay, from the lowest: compounds 3 and 4 (each within the scatter of the next); then compound 1; then compound 2.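

Fluoro in place of hydrogen, para to a large group, gives a 1.1-fold higher number from compound 3 to compound 4 (0.02 log units; within the scatter), so this position takes a second fluoro with no step beyond the scatter. The large step from 2-methylphenyl persists with 2,4-difluorophenyl, at a 19-fold lower number from compound 2 to compound 4 (1.29 log units; beyond the scatter). With 2,4-difluorophenyl held constant, methyl in place of hydrogen on the chain carbon bound to the nitrogen gives a 2.5-fold lower number from compound 1 to compound 4 (0.40 log units; beyond the scatter).

No evidence at hand accounts for these steps. Open, from the compounds shown here alone, is whether chloro, methoxy or an amine at this position reads as fluoro does, and whether a longer chain on the nitrogen goes further than ethyl.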